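This account rests on a few compounds, and the source may have more. Where it says the series, first, only, none or still open, it means among the compounds named here.

Measured in an ADME assay on MT4 cells (Homo sapiens) for cytotoxicity, read by MTT assay, with a stated time of 5 days; a higher number here means that more compound is tolerated, a lower number that less compound is tolerated:

- Compound 1 `COc1ccc(NC(=O)CSc2nc(Nc3c(C)cc(/C=C/C#N)cc3C)c3cc(OC)c(OC)cc3n2)cc1`: > 225000 nM, a limit of the assay
- Compound 2 `COc1cc2nc(SCC(=O)Nc3ccc(C(F)(F)F)cc3)nc(Nc3c(Cl)cc(/C=C/C#N)cc3Cl)c2cc1OC`: > 197000 nM, a limit of the assay
- Compound 3 `COc1cc2nc([S+]([O-])CC(=O)Nc3cccc(Cl)c3)nc(Nc3c(Cl)cc(/C=C/C#N)cc3Cl)c2cc1OC`: 68900 nM

Of these three results, only compound 3 has an actual number, 68900 nM. The results for compound 1 and compound 2 are limits, so neither gives an exact point of comparison.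

The next compound to be tested, compound 4 `COc1cc2nc([S+]([O-])CC(=O)Nc3cccc(C#N)c3)nc(Nc3c(Cl)cc(/C=C/C#N)cc3Cl)c2cc1OC`, keeps the structure of compound 3 except in one place. The change turns the 3-chlorophenyl into a 3-cyanophenyl: cyano in place of chloro on an aromatic carbon.

Within the data shown here, no two measured compounds differ in only one place, so the data show no measured size for a change of this kind. The closest guide is compound 3 at 68900 nM, since it is the compound nearest in structure. The expectation is therefore a change within the usual scatter of this assay, with no firm direction. A result reported only as a limit would also be no surprise. In numbers, the expected change is a 1.2-fold higher number from compound 3 to compound 4 (0.06 log units; within the scatter). Compound 4 is estimated at 80000 nM, with an expected range of 30000 nM to 216000 nM.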

Compound 4, half-maximal cytotoxic concentration: >= 70300 nM
Compound 4: no number, only a limit; the forecaster's own chance of this, stated with the estimate: 35%; the middle value does not contradict the limit.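

The result for compound 4 in this assay is a limit and not a number: the limit of >= 70300 nM in this assay, at which 1 of the 4 values shown sits. Even as a limit, it gives the first step between two compounds that differ in only one place, which none of the earlier compounds could offer: an at least 1.0-fold higher number from compound 3 to compound 4 (0.00 log units; that floor lies within the scatter). Cyano in place of chloro on this aromatic carbon, meta to a large group, therefore leaves the number no lower than that of compound 3, so the added nitrile does not make the compound less tolerated in this test, although the step has a floor and no measured size.

The compounds shown leave open whether the true value of compound 4 sits close to that of compound 3 or much higher, and so whether this change does anything measurable to tolerance at all. They also leave open how an amine or a carboxylic acid on the same aromatic carbon would behave, and whether either would move the number clearly away from that of compound 3.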